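From Phenylsulfonyl to (tert-Butyl)carbamoyl: A Cytotoxicity Step

The source may hold more compounds than are shown below. What is called first, only, known or untested is meant among the compounds shown, and "the series" means these compounds.

Measured so far:
- compound 1 `CC(C)(C)C(=O)N(CCCCCCN1C[C@H](O)[C@@H](O)[C@H](O)[C@H]1CO)C1CCCCC1`: > 500000 nM (a limit)
- compound 2 `CS(=O)(=O)N(CCCCCCN1C[C@H](O)[C@@H](O)[C@H](O)[C@H]1CO)C1CCCCC1`: > 500000 nM (a limit)
- compound 3 `O=S(=O)(c1ccccc1)N(CCCCCCN1C[C@H](O)[C@@H](O)[C@H](O)[C@H]1CO)C1CCCCC1`: 200000 nM

Among the compounds with values here, in an ADME assay on MDBK cells (Bos taurus) for cytotoxicity, read by MTT assay (on this read-out lower numbers stand for higher toxicity in this test and higher numbers for lower toxicity in this test), compound 3 gives 200000 nM, the only actual number and the lowest of the three. Compound 1 and compound 2 stand only at the limit of > 500000 nM in this assay, at which 2 of the 3 values shown sit.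

Compound 4 `CC(C)(C)NC(=O)N(CCCCCCN1C[C@H](O)[C@@H](O)[C@H](O)[C@H]1CO)C1CCCCC1` alters the group on the amine nitrogen: (tert-butyl)carbamoyl in place of phenylsulfonyl on an amine nitrogen. Within the data shown here, two measured steps bear on this change: an at least 2.5-fold lower number from compound 1 to compound 3 (0.39 log units; beyond the scatter) and an at least 2.5-fold lower number from compound 2 to compound 3 (0.39 log units; beyond the scatter). Both arrive at the phenylsulfonyl group, so removing it should reverse that fall, and a higher number of at least modest size is expected in this assay. The expected change is a 2.5-fold higher number from compound 3 to compound 4 (0.40 log units; beyond the scatter). For compound 4 the estimate is 500000 nM, with an expected range of 200000 nM to 1000000 nM.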

Compound 4, half-maximal cytotoxic concentration: > 500000 nM
Compound 4 ended at the assay's limit; the forecaster's own chance of this, stated with the estimate: 70%; the middle value lies on the limit itself.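

In this assay, the change on the amine nitrogen gives an at least 2.5-fold higher number from compound 3 to compound 4 (0.39 log units; beyond the scatter). Compound 4 thus becomes the third compound, with compounds 1 and 2, whose group on this nitrogen has no ring and whose result is a limit rather than a number, leaving phenylsulfonyl compound 3 alone with a measured value: the limit of > 500000 nM in this assay, at which 3 of the 4 values shown sit. The steps among compounds 1, 2 and 4 cannot be read.

The compounds shown leave open whether the lower number follows the phenyl ring or the sulfonyl linked to it. A benzoyl group on this nitrogen would separate the two.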